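Adding 3,5-dichlorophenyl to the benzyl series

The source may hold more compounds than are shown below. What is called first, only, known or untested is meant among the compounds shown, and "the series" means these compounds.

Measured so far in an ADME assay on cells (Hepatocyte, Homo sapiens) for metabolic stability, read by LC-MS, with a stated time of 3 h, tested at 1 uM; on this read-out lower numbers stand for slow clearance and higher numbers for fast clearance 
- compound 1 `CS(=O)(=O)NC(=O)c1cc(C2CC2)c(OCC2CCN(C(=O)c3cc(Cl)cc(Cl)c3)CC2)cc1F` 7.5 mL/min/kg 
- compound 2 `CS(=O)(=O)NC(=O)c1cc(C2CC2)c(OCC2CCN(Cc3ccccc3)CC2)cc1F` 15 mL/min/kg 

For the measured compounds named here, compound 2 stands within the scatter of compound 1, its only measured neighbour (a 2.0-fold higher number from compound 1 to compound 2 (0.30 log units; within the scatter)). Compound 3 `CS(=O)(=O)NC(=O)c1cc(C2CC2)c(OCC2CCN(Cc3cc(Cl)cc(Cl)c3)CC2)cc1F` differs from compound 2 by one change (3,5-dichlorophenyl in place of phenyl on a saturated chain carbon bound to an amine nitrogen in a ring): 3,5-dichlorophenyl in place of phenyl on a saturated chain carbon bound to an amine nitrogen in a ring. Going by the values given here, that single measured step, which exchanges (3,5-dichlorophenyl)carbonyl for benzyl, bears only indirectly, and no measured pair isolates the new change. No step beyond the scatter is therefore expected in this assay here. The estimated step is a 1.3-fold lower number from compound 2 to compound 3 (0.10 log units; within the scatter) and is expected to stay within the scatter. Compound 3 is expected at 12 mL/min/kg with an estimated range of 6 mL/min/kg to 24 mL/min/kg for now.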

Compound 3, clearance: 15 mL/min/kg
Compound 3: middle estimate off by 1.3-fold (0.10 log units), on the low side; low and high end bracket the measured number.
By their numbers in this assay, from the lowest: compounds 1, 2 and 3 (each within the scatter of the next).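

In this assay, for the compounds shown here, the first pair to isolate this change, 3,5-dichlorophenyl in place of phenyl on a saturated chain carbon bound to an amine nitrogen in a ring gives no change at the digits printed from compound 2 to compound 3 (within the scatter) at this position. With the 3,5-dichlorophenyl held constant, exchanging the carbonyl attachment for the benzyl attachment gives a 2.0-fold higher number from compound 1 to compound 3 (0.30 log units; within the scatter) and so also stays inside the scatter. Nothing on hand explains either step. Still open, from the compounds shown here alone, is whether a nitrile or methoxy group on the phenyl, or a longer chain to the amine nitrogen, would move the clearance beyond the scatter.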